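A few compounds are considered here, and "the series" means these few. Any claim that something is new, unique, unknown or untested is made for them only; others in the source may bear on it.

Measured compounds in the series:
- compound 1, `NS(=O)(=O)c1ccc(N2N=C(c3cccc(O)c3)C[C@H]2c2ccccc2Cl)cc1`: 70.3%
- compound 2, `COc1cc([C@@H]2CC(c3cccc(O)c3)=NN2c2ccc(S(N)(=O)=O)cc2)cc(OC)c1OC`: 74.4%

In a functional assay on the whole organism (strain Wistar albino) for inhibition, with Rattus norvegicus as the target, read by paw edema, with stated times of 30 min and 5 h, at a dose of 0.05 mmol/kg (on this read-out lower numbers stand for less inhibition and higher numbers for more inhibition at the one dose given (going by the name of the read-out)), compound 1 gives 70.3%, the lower of the two numbers on hand. In the same assay compound 2 gives 74.4%, a gap that lies within the usual scatter, so the two values show no order between them; both stand as substantial inhibition at the single dose. For the measured compounds named here, compound 2 differs from compound 1 in more than one place, so the two measured compounds give no single-point step to lean on.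

Compound 3, `NS(=O)(=O)c1ccc(N2N=C(c3cccc(O)c3)C[C@H]2c2ccco2)cc1`, is not yet measured. It differs from compound 1 in one place: furan-2-yl in place of 2-chlorophenyl on a saturated ring carbon. Going by the values given here, no measured pair covers this particular change, so the expectation rests only on the two values above and on the change itself. The step in this assay is expected to be a number 5.3 percentage points lower from compound 1 to compound 3 (within the scatter), a small shift toward less inhibition that is not expected to exceed the scatter. Compound 3 is expected to give 65%, within a range of 50% to 80%.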

Compound 3, a percentage reported as inhibition, in the whole organism at one dose (the size of the read-out at that dose, not a potency): 29.6%
For compound 3 the middle estimate is 35.4 percentage points above the measured one, outside the stated range (below it).
By their numbers in this assay, from the lowest: compound 3; then compounds 1 and 2 (each within the scatter of the next).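

In this assay, furan-2-yl in place of 2-chlorophenyl on the saturated ring carbon gives a number 40.7 percentage points lower from compound 1 to compound 3 (beyond the scatter), a large step from a single change in the shared core. This position is therefore not indifferent to the group it carries, at least in this pair: a change from one aromatic ring to another at this carbon is enough to move the read-out well beyond the scatter, which compound 1 and compound 2 could not show, since they differ in more than one place. Nothing on hand gives a measured reason for the step.

For the compounds shown here, the single step does not separate what leaves from what enters: it cannot say whether the drop goes with losing the chlorine, with the smaller ring, or with the ring oxygen, and unsubstituted phenyl, thiophen-2-yl or 2-methylphenyl at the same carbon would pull these apart. On these data alone, whether the step holds at other doses also stays open, as each number is the size of the read-out at one dose and not a potency.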